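A few compounds are considered here, and "the series" means these few. Any claim that something is new, unique, unknown or untested is made for them only; others in the source may bear on it.

The measured compounds:

compound 1 `O=C1c2ccccc2S(=O)(=O)N1CCCCCCN1CCN(c2cccc(Cl)c2Cl)CC1` gives 487 nM in an assay on HEK293 cells for displacement of a labelled ligand from 5-hydroxytryptamine receptor 7 (Homo sapiens); a lower number here means a stronger inhibitor, a higher number a weaker inhibitor
compound 2 `COc1ccccc1N1CCN(Cc2ccc(CN3C(=O)c4ccccc4S3(=O)=O)cc2)CC1` gives 97 nM in this assay
compound 3 `O=C1c2ccccc2S(=O)(=O)N1CCCCCCN1CCN(c2ncccn2)CC1` gives 2520 nM in this assay

Compound 3 stands at the highest number of the three in this assay; compound 1 is nearest to it and compound 2 furthest from it. For the measured compounds named here, the one step that joins measured compounds runs from compound 1 to compound 3 and is a 5.2-fold higher number from compound 1 to compound 3 (0.71 log units; beyond the scatter).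

Compound 4 `COc1ccccc1N1CCN(CCCCCCN2C(=O)c3ccccc3S2(=O)=O)CC1` differs from compound 3 in one place: 2-methoxyphenyl in place of pyrimidin-2-yl on an amine nitrogen in a ring. That step bears directly on the measured one, since it again exchanges the group on the same ring nitrogen, now going from the two-nitrogen ring back to a carbon-only ring. Compound 2 carries the same 2-methoxyphenyl group on a piperazine but reaches the shared core through a different chain, and in this assay compound 2 gives 97 nM. On these grounds a clear step to a lower number is expected from compound 3 to compound 4, a 32-fold lower number from compound 3 to compound 4 (1.50 log units; beyond the scatter). Compound 4 is therefore estimated at 80 nM, with a range from 20 nM to 400 nM.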

Compound 4, inhibition constant: 105 nM
The estimate for compound 4 lay 1.3-fold (0.12 log units) below the measured number, within the range that was stated.
By their numbers in this assay, from the lowest: compounds 2 and 4 (each within the scatter of the next); then compound 1; then compound 3.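

With the rest of the molecule unchanged, three groups on this amine nitrogen can now be ranked in this assay: there is a 24-fold lower number from compound 3 to compound 4 (1.38 log units; beyond the scatter), and a 4.6-fold lower number from compound 1 to compound 4 (0.67 log units; beyond the scatter), which places 2-methoxyphenyl lowest, 2,3-dichlorophenyl in the middle and pyrimidin-2-yl highest. The earlier step, a 5.2-fold higher number from compound 1 to compound 3 (0.71 log units; beyond the scatter), showed only that pyrimidin-2-yl gave the higher number of that pair, whereas these new steps show that a carbon-only aromatic ring with a different substituent can give a still lower number. Nothing shown here accounts for this order.

From the compounds shown here alone, it remains open whether the order would extend to other groups at this position, such as plain phenyl or pyridin-2-yl. Also open, going by these compounds, is whether 2-methoxyphenyl would keep its place on a shorter or longer chain.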